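Methoxy at the Benzyl Ring of an Oxadiazolone Core

This account rests on a few compounds, and the source may have more. Where it says the series, first, only, none or still open, it means among the compounds named here.

This account follows a small series built on a shared core, tested in an assay on COS-7 cells for inhibition of Fatty-acid amide hydrolase 1 (Homo sapiens), read by scintillation counting, with a stated time of 10 min, tested at 10 uM; a higher number here means more inhibition at the concentration tested (going by the name of the read-out), a lower number less inhibition. Compound 1 `COc1nn(Cc2ccccc2)c(=O)o1` carries an unsubstituted benzyl group; in this assay compound 1 gives "not active" (no number reported), so no single number stands for it. Two substituted relatives give numbers. Compound 2 `COc1nn(Cc2ccc(N)cc2)c(=O)o1` reaches 34% in this assay, while compound 3 `COc1nn(Cc2ccccc2NC(C)=O)c(=O)o1` gives 11% there. The two numbers are not the same, but no step between any pair of these compounds is established, so only the two values themselves are shown.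

Compound 4 `COc1cccc(Cn2nc(OC)oc2=O)c1` has not yet been measured. It differs from compound 1 by methoxy in place of hydrogen on an aromatic carbon. Nothing measured connects this particular change to the read-out of this assay; the nearest guide is that compound 1 shows no reported activity while its substituted relatives give only modest numbers. The step from compound 1 to compound 4 in this assay is therefore expected to be small, if any, and to stay within or only slightly beyond the usual scatter. Compound 4 is estimated to give about 12% in this assay, within a range of 0% to 30%.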

Compound 4, a percentage reported as inhibition, at one concentration (the size of the read-out at that concentration, not a potency): "not active" (no number reported)
The entry for compound 4 holds no number; the estimate stays without a comparison.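

Among the compounds shown here, neither compound 1 nor compound 4 yields a number in this assay and so no step between them can be read. No other data bear on this result. The compounds shown leave open whether methoxy in place of hydrogen changes inhibition in this assay on a compound that gives a number.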